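Phenyl gives way to pyrazolyl at the assay limit

A few compounds are considered here, and "the series" means these few. Any claim that something is new, unique, unknown or untested is made for them only; others in the source may bear on it.

Few measurements are available here, and one has no usable result. Compound 1 `CCN(c1cccc(-c2ccccc2)c1)c1ccc(C#N)c(Cl)c1` has the entry "not determined" (no result reported) in a functional assay on CWR22R cells (Homo sapiens) for antiproliferative activity, read by CCK-8 assay, with a stated time of 6 days (on this read-out lower numbers stand for stronger inhibition and higher numbers for weaker inhibition), and offers no comparison. Compound 2 `Cn1nccc1-c1cccc2c1CCCN2c1ccc(C#N)c(C(F)(F)F)c1` gives 10400 nM in this assay and carries a five-membered aromatic ring with 2 hetero atoms on its core. Compound 3 `CCN(c1ccc(C#N)c(Cl)c1)c1cc(-c2ccccc2)ccc1C` gives > 30000 nM as its entry, and this is a limit of the assay and not a number.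

Compound 4 `CCN(c1ccc(C#N)c(Cl)c1)c1cc(-c2cn[nH]c2)ccc1C` has 1H-pyrazol-4-yl in place of phenyl on an aromatic carbon, para to a methyl group, a change counted in full as 1H-pyrazol-4-yl in place of phenyl on an aromatic carbon (the rest of the molecule stays the same). Among the measured compounds shown here, no measured pair shows this swap directly, so any forecast is loose. For the measured compounds named here, the only guide is compound 2 at 10400 nM, which holds a similar ring and points to a modest gain in strength. The expected change is an estimated at least 3.0-fold lower number from compound 3 to compound 4 (0.47 log units; beyond the scatter) in that direction. For compound 4 the expected value is 10000 nM (estimated range 2500 nM to 30000 nM).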

Compound 4, half-maximal inhibitory concentration: > 30000 nM
Compound 4 was reported as a limit; the forecaster's own chance of this, stated with the estimate: 30%; at least 3.0-fold (0.47 log units) between middle value and limit.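

Compound 3 and compound 4 both stand at a limit of this assay and not at a number, so no step between them can be read: the limit of > 30000 nM in this assay, at which 2 of the 4 values shown sit.

The compounds shown leave open whether 1H-pyrazol-4-yl in place of phenyl changes the strength of inhibition at all.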